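The source may report more compounds than this note shows. Statements on the series, on what has been measured and on what is new or still open speak of the compounds shown alone.

Measured so far in an assay on L1.2 cells for binding affinity to C-C chemokine receptor type 8 (Homo sapiens); a higher number here means a weaker inhibitor, a lower number a stronger inhibitor:

- compound 1, `O=C(Nc1ccc(S(=O)(=O)N2CCCCC2)c2ccccc12)c1ccccc1`: only a limit, > 30000 nM
- compound 2, `CCOC(=O)N1CCC(NS(=O)(=O)c2ccc(O)c3ccccc23)CC1`: only a limit, > 5000 nM
- compound 3, `CCC(=O)N1CCC(NS(=O)(=O)c2ccc(NC(=O)c3ccccc3C)c3ccccc23)CC1`: 2.5 nM

Within the data shown here, compound 3 is the only one of the three that gives a number in this assay; compounds 1 and 2 reach no more than a limit, so no step between two measured compounds can be drawn here. Compound 3 therefore stands alone as the potent reference point.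

Compound 4, `CCCNC(=O)N1CCC(NS(=O)(=O)c2ccc(NC(=O)c3ccccc3C)c3ccccc23)CC1`, differs from compound 3 in one place: propylamino in place of ethyl on a carbonyl carbon. In other words the propanoyl group on the ring nitrogen becomes a propylcarbamoyl group, while the naphthalene sulfonamide and the methylbenzamide are kept exactly as they are in compound 3.

Among the measured compounds shown here, no measured pair shows what such a change does in this assay, so the expectation rests on the closeness of the two structures alone. Because compound 3 gives 2.5 nM and the change adds only a small piece at one end, the step from compound 3 to compound 4 is expected to be small, a 1.4-fold higher number from compound 3 to compound 4 (0.15 log units; within the scatter), and not beyond the usual scatter in either direction. For compound 4 the estimate in this assay is 3.5 nM, with a range from 1 nM to 15 nM.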

Compound 4, inhibition constant: 77.4 nM
Compound 4: middle estimate off by 22-fold (1.34 log units), on the low side; the measured number lies above the stated range.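

In this assay, the position on this carbonyl carbon turns out to be sensitive, as replacing ethyl with propylamino, which turns propanoyl into propylcarbamoyl, gives a 31-fold higher number from compound 3 to compound 4 (1.49 log units; beyond the scatter) while the rest of the structure stays the same. Among these compounds, this is the first readable step, and it shows that a change confined to one end of the molecule can shift the number well beyond the scatter, although compound 4 still gives a real value of 77.4 nM rather than a limit. The change brings in one hydrogen-bond donor and a larger group at once, and nothing measured here explains why this step is so large.

Among the compounds shown here, the single step leaves open how much of the loss goes with the entering nitrogen and how much with the longer chain, a question that a butanoyl group, an ethylamino group or a dimethylamino group at the same place could help to separate. Also open, going by these compounds, is whether a shorter group such as acetyl, or an ethoxy group with the rest of compound 3 kept, would stay close to compound 3 or fall towards compound 4.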